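The source may hold more compounds than are shown below. What is called first, only, known or untested is meant among the compounds shown, and "the series" means these compounds.

Measured in a functional assay on HL-60 cells (Homo sapiens) for antiproliferative activity, read by sulforhodamine B assay, with a stated time of 72 h; a lower number here means a stronger inhibitor, a higher number a weaker inhibitor:
- compound 1 `S=C(NCc1ccccc1)N/N=C/c1ccc2ccccc2n1`: 21900 nM
- compound 2 `Fc1cccc(NC(=S)N/N=C/c2ccc3ccccc3n2)c1`: 43800 nM

Compound 2, at 43800 nM, lies within the scatter of compound 1, so the two numbers do not separate. The next compound is compound 3 `COc1ccc(NC(=S)N/N=C/c2ccc3ccccc3n2)cc1`. The change is 4-methoxyphenyl in place of 3-fluorophenyl on an amide-type nitrogen, whose other neighbour is the thiocarbonyl carbon.

For the measured compounds named here, only one measured step bears on this place: a 2.0-fold higher number from compound 1 to compound 2 (0.30 log units; within the scatter). That step also exchanged the group on this nitrogen, and it stayed within the scatter. Going by the values given here, no measured compound carries the 4-methoxyphenyl group, and a single step shows little of how far a change here can move the number in this assay. A step beyond the scatter is therefore not expected, although the range has to stay wide.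

The expected step is a 1.5-fold lower number from compound 2 to compound 3 (0.16 log units; within the scatter). For compound 3 the estimated value is 30000 nM, with an expected range of 10000 nM to 80000 nM.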

Compound 3, half-maximal inhibitory concentration: 43800 nM
The estimate for compound 3 lay 1.5-fold (0.16 log units) below the measured number; the measured number falls inside the stated range.
By their numbers in this assay, from the lowest: compounds 1, 2 and 3 (each within the scatter of the next).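

In this assay, 4-methoxyphenyl in place of 3-fluorophenyl on the amide-type nitrogen gives no change at the digits printed from compound 2 to compound 3 (within the scatter) and 4-methoxyphenyl in place of benzyl gives a 2.0-fold higher number from compound 1 to compound 3 (0.30 log units; within the scatter) so the three groups now tested at this place do not separate. Compared with the earlier pair, this adds a second aromatic group with a different substituent, and the exchange of fluorine-bearing 3-fluorophenyl for 4-methoxyphenyl, with its one hydrogen-bond acceptor, still leaves the number within the scatter. The data shown offer no measurement that would explain this lack of separation.

Going by these compounds, it remains open whether any group on this nitrogen can move the number beyond the scatter, since all three carry a six-membered aromatic ring of carbon only, and a small methyl group, a basic chain ending in a dimethylamino group or a phenyl ring bearing a carboxylic acid could test this. Also open, on these data alone, is how much of the level shared by all three compounds belongs to the core and the thiocarbonyl, which stay the same throughout this set.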